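Chain length at the piperidine amide, compared across two cores

A few compounds are considered here, and "the series" means these few. Any claim that something is new, unique, unknown or untested is made for them only; others in the source may bear on it.

Compound 1 `CC(CC(=O)O)N1Cc2ccc(NC(=O)CC3CCNCC3)cc2C1=O` serves as the reference of the set. In a functional assay on a cell-free system (Platelet, plasma, Homo sapiens) for inhibition (a higher number here means a weaker inhibitor, a lower number a stronger inhibitor), compound 1 gives 2700 nM. Compound 2 `CC(CC(=O)O)N1Cc2ccc(NC(=O)CCCC3CCNCC3)cc2C1=O` carries the change (2-(piperidin-4-yl)ethyl in place of piperidin-4-yl on a saturated chain carbon bound to a carbonyl carbon). In this assay compound 2 gives 5400 nM, so the step is a 2.0-fold higher number from compound 1 to compound 2 (0.30 log units; within the scatter).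

Compound 3 `O=C(O)CCN1Cc2ccc(NC(=O)CC3CCNCC3)cc2C1=O` differs from compound 1 in its core: hydrogen in place of methyl on a saturated chain carbon bound to an amide-type nitrogen in a ring and a saturated chain carbon. In this assay compound 3 gives 7400 nM, which corresponds to a 2.7-fold higher number from compound 1 to compound 3 (0.44 log units; beyond the scatter). Compound 3 thus carries the highest number of the three measured compounds, though its gap to compound 2 lies within the scatter.

Compound 4 `O=C(O)CCN1Cc2ccc(NC(=O)CCCC3CCNCC3)cc2C1=O` has not been measured. It relates to compound 3 by the change (2-(piperidin-4-yl)ethyl in place of piperidin-4-yl on a saturated chain carbon bound to a carbonyl carbon), and the place of the change is the same word for word as in the pair of compound 1 and compound 2, so it is the same change on the other core. It occurs twice among the compounds shown. Going by the values given here, only one measured instance exists, and it is within the scatter, so the direction of the step is not firmly established; the expectation rests on that single pair and on the value of compound 3 7400 nM.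

Among the compounds with values here, for compound 4 the expected step in this assay is a 1.9-fold higher number from compound 3 to compound 4 (0.28 log units; within the scatter), set beside the earlier step of a 2.0-fold higher number from compound 1 to compound 2 (0.30 log units; within the scatter) as the only precedent. Compound 4 is therefore estimated at 14000 nM, with the likely range 5000 nM to 40000 nM.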

Compound 4, half-maximal inhibitory concentration: 5900 nM
Compound 4: the middle estimate sits 2.4-fold (0.38 log units) above what was measured; the range from low to high includes it.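

In this assay, extending piperidin-4-yl to 2-(piperidin-4-yl)ethyl on the core of compound 3 gives a 1.3-fold lower number from compound 3 to compound 4 (0.10 log units; within the scatter), and this step does not differ measurably from its counterpart on the core of compound 1: the same change on two cores in this assay, a 2.0-fold higher number (0.30 log units; within the scatter) from compound 1 to compound 2 and a 1.3-fold lower number (0.10 log units; within the scatter) from compound 3 to compound 4, 2.5-fold (0.40 log units) apart, within the scatter of two such steps. Replacing methyl with hydrogen on the longer chain gives a 1.1-fold higher number from compound 2 to compound 4 (0.04 log units; within the scatter), and this step also cannot be told apart from its counterpart on the shorter chain: the same change on two cores in this assay, a 2.7-fold higher number (0.44 log units; beyond the scatter) from compound 1 to compound 3 and a 1.1-fold higher number (0.04 log units; within the scatter) from compound 2 to compound 4, 2.5-fold (0.40 log units) apart, within the scatter of two such steps. Within these four compounds, therefore, neither change can be shown to depend on the other, but this does not establish that the steps carry over unchanged, as each comparison rests on a single pair of steps and a 2.7-fold higher number from compound 1 to compound 3 (0.44 log units; beyond the scatter) is the only one of the four beyond the scatter.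

The compounds shown leave open whether a chain longer than 2-(piperidin-4-yl)ethyl, or an open-chain amine in place of the piperidine, would produce a step beyond the scatter on either core. They also leave open whether ethyl in place of methyl on the carbon bearing the ring amide nitrogen would extend the step seen with the shorter chain, and whether it would do so with the longer chain as well.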